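The source may report more compounds than this note shows. Statements on the series, on what has been measured and on what is new or still open speak of the compounds shown alone.

Measured so far:
compound 1 `N=C(N)c1ccc(-c2ccc(-c3cc(Cl)cc(Cl)c3)s2)cc1` — 375 nM
compound 2 `N=C(N)c1ccc(-c2ccc(-c3ccc(F)cc3)s2)cc1` — 392 nM
compound 3 `N=C(N)c1ccc(-c2ccc(-c3ccc(Cl)cc3)s2)cc1F` — 207 nM

In a functional assay on NCI-H460 cells (Homo sapiens) for inhibition, read by sulforhodamine B assay, with a stated time of 48 h (a lower number here means a stronger inhibitor of growth, a higher number a weaker inhibitor of growth), compound 1 gives 375 nM and compound 2 gives 392 nM. Compound 3 gives 207 nM, the lowest of the three numbers, but its gaps to compound 1 and to compound 2 both lie within the scatter, so no order among the three compounds is claimed.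

Compound 4 `N=C(N)c1ccc(-c2ccc(-c3ccccc3)s2)cc1F` is the next compound, differing from compound 3 in one place: hydrogen in place of chloro on an aromatic carbon. Going by the values given here, no pair of measured compounds differs from each other in a single place, so there is no measured step to lean on. The three measured compounds all carry a halogen on the outer ring; compound 4 carries none. On that basis the step in this assay is expected to be a small one toward a higher number, of a size that may stay within the scatter.

The step from compound 3 to compound 4 is estimated as a 1.7-fold higher number from compound 3 to compound 4 (0.23 log units; within the scatter). Compound 4 is accordingly expected to give 350 nM in this assay, within a range of 150 nM to 900 nM.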

Compound 4, concentration for 50% growth inhibition: 3690 nM
Beside the measured number, compound 4's estimate is 11-fold (1.02 log units) below it; measured number above the stated range.
By their numbers in this assay, from the lowest: compounds 3, 1 and 2 (each within the scatter of the next); then compound 4.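

In this assay, going by these compounds alone, the change from 4-chlorophenyl to phenyl gives an 18-fold higher number from compound 3 to compound 4 (1.25 log units; beyond the scatter), and this is the first step that can be read at a single place. The earlier compounds shown here, with no single-place pair among them, could not show that the number depends this strongly on the chloro at this aromatic carbon, para to a large group. Nothing measured here accounts for the size of this step.

As far as these compounds go, whether a methyl, a methoxy or an amine at this carbon would keep the number close to that of compound 3 stays open. Also open, from the compounds shown here alone, is whether the step would keep its size in a compound without the fluoro that compound 3 and compound 4 share.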